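The compounds below may be only part of what the source reports. "The series", "measured", "known", "first", "only" and "open" are said of these compounds alone.

Working notes on the series. Compound 1 `Cc1csc2cc([C@H](C)Nc3ncnc(N)c3C#N)c(-c3cccc(CN4CCC(CN(C)Cc5ccccn5)CC4)c3)c(=O)n12` gives 2 in a physicochemical assay for lipophilicity; on this read-out lower numbers stand for lower lipophilicity and higher numbers for higher lipophilicity; compound 2 `Cc1csc2cc([C@H](C)Nc3ncnc(N)c3C#N)c(-c3cccc(CN(C)CCCN(C)Cc4ccc(Cl)cc4)c3)c(=O)n12` gives 3.2; compound 3 `Cc1csc2cc([C@H](C)Nc3ncnc(N)c3C#N)c(Cc3cccc(CN(C)CC(C)C)c3)c(=O)n12` gives 2.3. Of the three numbers, that of compound 3 is the second highest: the reading of compound 1 sits within the usual scatter of it, while compound 2 stands higher by a margin beyond the scatter.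

Compound 4 `Cc1csc2cc([C@H](C)Nc3ncnc(N)c3C#N)c(Cc3cccc(CN(C)C)c3)c(=O)n12` is not yet measured. It differs from compound 3 by one change: hydrogen in place of isopropyl on a saturated chain carbon bound to an amine nitrogen. For the measured compounds named here, no step of this kind is available among the measured compounds, so the expectation rests on the size of the group that leaves. A drop beyond the scatter is expected, the step from compound 3 to compound 4 being about a number 1.20 log units lower from compound 3 to compound 4 (beyond the scatter). Compound 4 is therefore estimated at 1.1, within 0.4 to 1.8.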

Compound 4, distribution coefficient: 0.8
For compound 4 the middle estimate is 0.30 log units above the measured one; low and high end bracket the measured number.
By their numbers in this assay, from the lowest: compound 4; then compounds 1 and 3 (each within the scatter of the next); then compound 2.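

In this assay, the first step read at this position is hydrogen in place of isopropyl on a saturated chain carbon bound to an amine nitrogen, and it gives a number 1.50 log units lower from compound 3 to compound 4 (beyond the scatter). The read-out at this place therefore moves beyond the scatter on the loss of a group of 3 carbon atoms, with no ring and no hydrogen-bond donors or acceptors. No measurement bearing on the origin of this step is at hand.

For the compounds shown here, with only this one step, how the number changes along the way from isopropyl to hydrogen stays open. An ethyl, a cyclopropyl or a hydroxyethyl group at this place could show whether size alone tracks the read-out.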